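The source may report more compounds than this note shows. Statements on the series, on what has been measured and on what is new or still open speak of the compounds shown alone.

Measured compounds:
compound 1 `COc1cc2c(cc1OC)C(c1ccc(N)cc1)=NN=C(S)C2` — 6.3 umol/kg
compound 2 `COc1cc2c(cc1OC)C(c1ccc([N+](=O)[O-])cc1)=NN=C(S)C2` — 93.4 umol/kg
compound 3 `COc1cc2c(cc1OC)C(c1ccc(N)cc1)=NN(C)C(=S)C2` — 29.8 umol/kg

All three were run in a functional assay on the whole organism with Mus musculus as the target; a higher number here means that more compound is needed for the effect, a lower number that less compound is needed. Compound 1 and compound 2 share one core and differ by nitro in place of amino on an aromatic carbon; this change gives a 15-fold higher number from compound 1 to compound 2 (1.17 log units; beyond the scatter). Compound 3 carries another core; the difference between the core of compound 3 and the core of compound 1 is not broken down here. In this assay compound 3 gives 29.8 umol/kg, a number standing between the other two: higher than that of compound 1 and lower than that of compound 2, both gaps lying beyond the scatter.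

Compound 4 `COc1cc2c(cc1OC)C(c1ccc([N+](=O)[O-])cc1)=NN(C)C(=S)C2` has not yet been measured. It differs from compound 3 by nitro in place of amino on an aromatic carbon, the same change as that made from compound 1 to compound 2; among these compounds the change appears in two pairs. What can be expected of it rests on a single measured instance on a different core, so the size may not carry over exactly. The step from compound 3 to compound 4 is expected to be a 12-fold higher number from compound 3 to compound 4 (1.07 log units; beyond the scatter), in the same direction as the earlier step and of a comparable size, because a 15-fold higher number from compound 1 to compound 2 (1.17 log units; beyond the scatter) is large and lies well beyond the scatter. On this basis the value of compound 4 in this assay is estimated at 350 umol/kg, with a likely range from 120 umol/kg to 1000 umol/kg.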

Compound 4, dose for half-maximal effect: 103 umol/kg
The estimate for compound 4 lay 3.4-fold (0.53 log units) above the measured number, outside the stated range (below it).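

In this assay, nitro in place of amino on an aromatic carbon gives a 3.5-fold higher number from compound 3 to compound 4 (0.54 log units; beyond the scatter) on this second core, so the direction of the change is the same in both pairs, with the amino compound needing less compound for the effect each time. The size of the step, however, does not carry over intact from one core to the other: the same change on two cores in this assay, a 15-fold higher number (1.17 log units; beyond the scatter) from compound 1 to compound 2 and a 3.5-fold higher number (0.54 log units; beyond the scatter) from compound 3 to compound 4, 4.3-fold (0.63 log units) apart, beyond the scatter of two such steps. These two pairs therefore support carrying the direction of this change between the two cores, but they do not show what sets the size of the step, and they give no basis for predicting its size on a further core.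

The amino and nitro groups are the only two substituents shown at this place on the six-membered aromatic ring, so it remains open how a dimethylamino group, an acetamide, a carboxylic acid or a chlorine atom would behave there on either core. Going by these compounds, it is also open whether the direction seen in these two pairs would hold on a third core, and whether the gap between the two step sizes would recur with any other pair of groups.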